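Removing one methyl from the amino group of compound 2

The source may hold more compounds than are shown below. What is called first, only, known or untested is meant among the compounds shown, and "the series" means these compounds.

Measured compounds:
compound 1, `Nc1nc(N)c2c(-c3cc4ccccc4o3)cn([C@@H]3O[C@H](CO)[C@@H](O)[C@H]3O)c2n1`: > 15000 nM
compound 2, `CN(C)c1ncnc2c1c(-c1cc3ccccc3o1)cn2[C@@H]1O[C@H](CO)[C@@H](O)[C@H]1O`: > 20000 nM
compound 3, `C#Cc1cn([C@@H]2O[C@H](CO)[C@@H](O)[C@H]2O)c2ncnc(N(C)C)c12`: 290 nM

Compound 2, `CN(C)c1ncnc2c1c(-c1cc3ccccc3o1)cn2[C@@H]1O[C@H](CO)[C@@H](O)[C@H]1O`, carries a dimethylamino group and a 1-benzofuran-2-yl group on its core. In a functional assay on HL-60 cells (Homo sapiens) for antiproliferative activity, read by XTT assay, with a stated time of 72 h (on this read-out higher numbers stand for weaker inhibition and lower numbers for stronger inhibition), compound 2 reaches only a limit, > 20000 nM, and gives no number. Compound 1, which also carries the 1-benzofuran-2-yl group, likewise stops at a limit of > 15000 nM. Going by the values given here, compound 3 is the one measured compound with a number, 290 nM. Among the compounds with values here, the single step with both ends measured runs an at least 68-fold lower number from compound 2 to compound 3 (1.83 log units; beyond the scatter), and it concerns the aromatic carbon, not the amino nitrogen.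

Compound 4, `CNc1ncnc2c1c(-c1cc3ccccc3o1)cn2[C@@H]1O[C@H](CO)[C@@H](O)[C@H]1O`, differs from compound 2 by hydrogen in place of methyl on a nitrogen on an aromatic ring: the dimethylamino becomes methylamino while the 1-benzofuran-2-yl group stays. Within the data shown here, no measured step touches that nitrogen, so nothing measured points to a change in either direction. Both measured compounds bearing the 1-benzofuran-2-yl group sit at limits, the limit of > 15000 nM in this assay, at which 1 of the 3 values shown sits, and (the limit of > 20000 nM in this assay, at which 1 of the 3 values shown sits). Compound 4 is therefore expected to stay near the limit of compound 2, with an estimated step of a number no higher from compound 2 to compound 4 (the limit leaves the size open). The estimate for compound 4 in this assay is 20000 nM, within a range from 5000 nM to 60000 nM, and most likely again only a limit.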

Compound 4, half-maximal inhibitory concentration: 8950 nM
Beside the measured number, compound 4's estimate is 2.2-fold (0.35 log units) above it, and the stated range covers the measured number.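

Hydrogen in place of methyl on a nitrogen on an aromatic ring brings, in this assay, an at least 2.2-fold lower number from compound 2 to compound 4 (0.34 log units; beyond the scatter), so this nitrogen, which no earlier step had touched, also bears on the read-out. Compound 4 gives 8950 nM, which makes it the first compound shown with the 1-benzofuran-2-yl group to give a number, so that group does not by itself keep a compound from giving one. The true size of the step stays open, since the value of compound 2 is a limit: the limit of > 20000 nM in this assay, at which 1 of the 4 values shown sits.

The compounds shown leave open whether a longer chain on this nitrogen, such as ethylamino, or a plain amino group in its place would move the number further while the 1-benzofuran-2-yl group stays. They also leave open whether dimethylamino to methylamino brings a similar step in a compound that carries ethynyl, as compound 3 does, on the aromatic carbon.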